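The source may hold more compounds than are shown below. What is called first, only, known or untested is meant among the compounds shown, and "the series" means these compounds.

Measured so far in a functional assay (Homo sapiens) for antiproliferative activity, read by resazurin assay, with a stated time of 48 h, tested at 5 uM; a higher number here means a stronger effect of the compound at the concentration tested, a lower number a weaker effect:

compound 1, `COc1cc(OC)c2c(=O)cc(-c3ccc(OCCN)cc3)oc2c1`, gives 6%;
compound 2, `COc1cc(OC)c2c(=O)cc(-c3ccc(OCC(O)CN(C)C)cc3)oc2c1`, gives 42%.

Of the two numbers, compound 2 stands higher: the move a number 36 percentage points higher from compound 1 to compound 2 (beyond the scatter) is beyond the scatter, so compound 2 is the stronger of the pair in this assay.

Compound 3, `COc1cc(OC)c2c(=O)cc(-c3ccc(OCC(O)CO)cc3)oc2c1`, has not yet been measured. It differs from compound 2 in one place: hydroxy in place of dimethylamino on a saturated chain carbon, two bonds along the chain from an oxygen on a saturated carbon. Read one bond further out, the 2-(dimethylamino)-1-hydroxyethyl of compound 2 becomes a 1,2-dihydroxyethyl in compound 3.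

Going by the values given here, only one measured step touches this part of the molecule. From compound 1 to compound 2 the amine end of the chain was changed and the hydroxy added at once, and the effect was large. That step does not separate the share of the dimethylamino from the share of the hydroxy, so it gives no direct guide to taking the dimethylamino away while keeping the hydroxy. With compound 1, which also lacks a dimethylamino, standing low, a fall in this assay is expected for compound 3, a number 27 percentage points lower from compound 2 to compound 3 (beyond the scatter). The estimate for compound 3 is 15%, with a range from 0% to 40%.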

Compound 3, a percentage reported as inhibition, at one concentration (the size of the read-out at that concentration, not a potency): "not active" (no number reported)
The entry for compound 3 holds no number; there is nothing to compare the estimate with.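

Going by these compounds alone, compound 3 is reported only as "not active", with no number, so no step from compound 2 to compound 3 can be read. The compounds shown leave open how much of the rise from compound 1 to compound 2 belongs to the dimethylamino and how much to the hydroxy. No measurement shown here accounts for the result of compound 3.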